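The source may report more compounds than this note shows. Statements on the series, on what has been measured and on what is new or still open speak of the compounds shown alone.

Series values in a functional assay on DU-145 cells (Homo sapiens) for inhibition, read by trypan blue exclusion, with a stated time of 96 h; a higher number here means a weaker inhibitor of growth, a lower number a stronger inhibitor of growth:
- compound 1 `COc1ccccc1/C=C(/SCc1ccc(F)cc1)C(=O)c1ccc(Br)cc1`: 10000 nM
- compound 2 `O=C(/C(=C\c1ccc(O)cc1)SCc1ccc(F)cc1)c1ccc(Br)cc1`: 10000 nM
- compound 3 `Cc1ccsc1/C=C(/SCc1ccc(F)cc1)C(=O)c1ccc(Br)cc1`: 50000 nM

In this assay compound 2 gives 10000 nM, level with compound 1, and the two share the lowest of the three numbers. The next compound, compound 4 `O=C(/C(=C\c1ccc(O)cc1)SCc1ccc(F)cc1)c1ccc(Cl)cc1`, is not yet measured. It keeps the core of compound 2 and changes only the halogen: chloro in place of bromo on an aromatic carbon. This is chloro in place of bromo on an aromatic carbon, para to a large group.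

For the measured compounds named here, no measured step touches this position. All three vary the group on the double-bonded chain carbon instead. They are no change at the digits printed from compound 1 to compound 2 (within the scatter), a 5.0-fold higher number from compound 1 to compound 3 (0.70 log units; beyond the scatter) and a 5.0-fold higher number from compound 2 to compound 3 (0.70 log units; beyond the scatter). The largest of these is modest and involves a whole ring group, not a single atom, so the series offers no direct measure of a halogen exchange. With no such evidence, the anchor is compound 2 at 10000 nM, and no step beyond the scatter is expected in this assay, in either direction. The expected change is no change at the digits printed from compound 2 to compound 4 (within the scatter). For compound 4 the estimated value is 10000 nM, with an expected range of 4000 nM to 25000 nM.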

Compound 4, concentration for 50% growth inhibition: 25000 nM
Compound 4: middle estimate off by 2.5-fold (0.40 log units), on the low side; measured number inside the range.
By their numbers in this assay, from the lowest: compounds 1 and 2 (each within the scatter of the next); then compounds 4 and 3 (each within the scatter of the next).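

In this assay, the halogen position proves not to be silent: chloro in place of bromo gives a 2.5-fold higher number from compound 2 to compound 4 (0.40 log units; beyond the scatter). For the compounds shown here, this is the first measured step at this position, as all earlier steps varied the group on the double-bonded chain carbon, and it shows that the 4-bromophenyl to 4-chlorophenyl exchange, 1 heavy atom for 1 heavy atom on an aromatic carbon, para to a large group, is enough to move the number beyond the scatter. Bromo is therefore the better of the two halogens here with the 4-hydroxyphenyl group in place, though the step is modest and nothing at hand accounts for it.

With only bromo and chloro shown, a single pair gives no trend at this position, and how a fluoro, iodo, methyl or trifluoromethyl group would read remains open. Going by these compounds, it is also open whether the same halogen exchange gives a step of similar size with 2-methoxyphenyl or 3-methylthiophen-2-yl on the chain carbon, or whether it depends on the 4-hydroxyphenyl group.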